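Aryl swap on the benzylamide of compound 3

This account rests on a few compounds, and the source may have more. Where it says the series, first, only, none or still open, it means among the compounds named here.

Compound 1 is `COc1ccc(CNC(=O)c2cccc(C(C)Oc3ccnc(Nc4cnn(C)c4)c3)c2)cc1OC` and in a functional assay on HCC78 cells (Homo sapiens) for antiproliferative activity, read by MTT assay, with a stated time of 48 h (on this read-out lower numbers stand for stronger inhibition and higher numbers for weaker inhibition), compound 1 gives 76600 nM. Compound 2 is `Cc1ccc(CNC(=O)c2cccc(C(C)Oc3ccnc(Nc4cnn(C5CCN(C)CC5)c4)c3)c2)cc1` and in this assay compound 2 gives 8100 nM. Compound 3 is `CC(Oc1ccnc(Nc2cnn(C3CCN(C)CC3)c2)c1)c1cccc(C(=O)NCc2ccc(Cl)c(C(F)(F)F)c2)c1` and in this assay compound 3 gives 7300 nM.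

In this assay compound 3 gives the lowest of the three numbers, but compound 2 sits within the scatter of it, separated only by a 1.1-fold lower number from compound 2 to compound 3 (0.05 log units; within the scatter); compound 1 lies much further away, beyond the scatter. Compound 4 is `COc1ccc(CNC(=O)c2cccc(C(C)Oc3ccnc(Nc4cnn(C5CCN(C)CC5)c4)c3)c2)cc1OC`, and the change from compound 3 reads (3,4-dimethoxyphenyl in place of 4-chloro-3-(trifluoromethyl)phenyl on a saturated chain carbon bound to an amide-type nitrogen). Among the measured compounds shown here, the one measured step at this position, a 1.1-fold lower number from compound 2 to compound 3 (0.05 log units; within the scatter), barely moved the read-out. Compound 1 also bears the 3,4-dimethoxyphenyl group yet differs from compound 3 in a second place, and compound 1 gives 76600 nM. Compound 4 is therefore expected to show a 1.5-fold higher number from compound 3 to compound 4 (0.18 log units; within the scatter), an estimate of 11000 nM within 3500 nM to 40000 nM.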

Compound 4, half-maximal inhibitory concentration: 9000 nM
Beside the measured number, compound 4's estimate is 1.2-fold (0.09 log units) above it; low and high end bracket the measured number.
By their numbers in this assay, from the lowest: compounds 3, 2 and 4 (each within the scatter of the next); then compound 1.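

In this assay, the 3,4-dimethoxyphenyl group sits within the scatter of both other aryl groups at this position, with a 1.2-fold higher number from compound 3 to compound 4 (0.09 log units; within the scatter) and a 1.1-fold higher number from compound 2 to compound 4 (0.05 log units; within the scatter). Among the compounds shown here, with that aryl group held constant, 1-methylpiperidin-4-yl in place of methyl on an aromatic nitrogen gives an 8.5-fold lower number from compound 1 to compound 4 (0.93 log units; beyond the scatter), so the one step beyond the scatter lies at that nitrogen, not on the benzylamide. Nothing available explains either outcome. Still open, on these data alone, is whether an amine or a carboxylic acid on this aryl ring, or a longer chain in place of the benzyl carbon, would shift the number.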